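Taking the nitro group off compound 2

A few compounds are considered here, and "the series" means these few. Any claim that something is new, unique, unknown or untested is made for them only; others in the source may bear on it.

Measured so far:
Compound 1 `CCCCn1cc(C(=O)O)c(=O)c2cc(F)c(N3CCC(C(N)=O)CC3)cc21`: > 100000 nM
Compound 2 `CCCCn1cc(C(=O)NCc2ccc(OC)c([N+](=O)[O-])c2)c(=O)c2cc(F)c(N3CCC(C(N)=O)CC3)cc21`: > 100000 nM

Both entries come from an ADME assay on J774.1 cells (Mus musculus) for cytotoxicity, read by resazurin assay, with a stated time of 48 h; a lower number here means a stronger inhibitor, a higher number a weaker inhibitor. For compound 1, the entry > 100000 nM is a limit of the assay and not a number. For compound 2, the entry > 100000 nM is likewise a limit and not a number. The picture so far is therefore (the limit of > 100000 nM in this assay, at which 2 of the 2 values shown sit), and the numbers do not separate the two compounds.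

Compound 3 `CCCCn1cc(C(=O)NCc2ccc(OC)cc2)c(=O)c2cc(F)c(N3CCC(C(N)=O)CC3)cc21` differs from compound 2 in one place. It has hydrogen in place of nitro on an aromatic carbon, ortho to a methoxy group (hydrogen in place of nitro on an aromatic carbon), so the 4-methoxy-3-nitrobenzyl group becomes a 4-methoxybenzyl group.

Among the compounds with values here, no measured pair shows what this change does, so the expectation rests only on both measured compounds sitting at the same limit. In this assay, the expected outcome is a number no higher from compound 2 to compound 3 (the limit leaves the size open), with no change beyond the scatter and no favoured direction. A second result reported only as a limit would be the likeliest outcome. For compound 3, the estimated value is 100000 nM, with an expected range from 40000 nM to 200000 nM.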

Compound 3, half-maximal inhibitory concentration: 40800 nM
Estimate against measurement, compound 3: 2.5-fold (0.39 log units) above, within the range that was stated.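

In this assay, within the data shown here, the swap of nitro for hydrogen on the aromatic carbon ortho to a methoxy group gives an at least 2.4-fold lower number from compound 2 to compound 3 (0.38 log units; beyond the scatter), and it brings the first reading in this set that is a number and not a limit. The (4-methoxybenzyl)amino group in place of hydroxy on the carbonyl carbon gives an at least 2.4-fold lower number from compound 1 to compound 3 (0.38 log units; beyond the scatter), yet compound 2 also carries an amide there, so the amide alone does not produce a readable effect on these cells and the group on that aromatic carbon matters as well. Going by these compounds, the true size of both steps stays open because each starts from a limit and not from a number: the limit of > 100000 nM in this assay, at which 2 of the 3 values shown sit.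

On these data alone, whether a chlorine atom or a nitrile on that same aromatic carbon would behave like the hydrogen of compound 3 or like the nitro group of compound 2 remains open. So does the part played by the methoxy group, which a plain benzyl amide or a longer chain between the amide and the aromatic ring would help to separate from the rest of the side chain.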